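The compounds below may be only part of what the source reports. "The series", "measured", "known", "first", "only" and "open" are said of these compounds alone.

In a functional assay on PC-3 cells (Homo sapiens) for inhibition, read by MTT assay, with a stated time of 72 h (a higher number here means a weaker inhibitor, a lower number a stronger inhibitor), the measured compounds stand as follows:

Compound 1 `Cc1ccc(-n2cc(CNC(=O)c3cccc4c3cnn4C(C)C)nn2)cc1C` gives 23400 nM.
Compound 2 `CC(C)n1ncc2c(C(=O)NCc3cn(-c4ccc(I)cc4)nn3)cccc21` reaches only the limit of the assay, > 40000 nM.
Compound 3 `CC(C)n1ncc2c(C(=O)NCc3cn(-c4cccc(Br)c4)nn3)cccc21` gives 33700 nM.

Compound 2 therefore stands at the edge of what this assay reports, a limit rather than a number (the limit of > 40000 nM in this assay, at which 1 of the 3 values shown sits). Its neighbours move little: the step from compound 1 to compound 2 is an at least 1.7-fold higher number from compound 1 to compound 2 (0.23 log units; that floor lies within the scatter), the step from compound 2 to compound 3 is an at least 1.1-fold lower number from compound 2 to compound 3 (0.07 log units; that floor lies within the scatter), and the step from compound 1 to compound 3 is a 1.4-fold higher number from compound 1 to compound 3 (0.16 log units; within the scatter). All three changes swap one substituted phenyl for another on the aromatic nitrogen, and none of them leaves the scatter.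

Compound 4 `COc1ccc(Cn2cc(CNC(=O)c3cccc4c3cnn4C(C)C)nn2)cc1` differs from compound 2 in one place: 4-methoxybenzyl in place of 4-iodophenyl on an aromatic nitrogen. Among the compounds with values here, no measured step exchanges a phenyl for a benzyl, so the nearest evidence is the set of phenyl swaps above, all flat. The expected step from compound 2 to compound 4 is accordingly an at least 1.1-fold lower number from compound 2 to compound 4 (0.05 log units; that floor lies within the scatter), that is, nothing beyond the scatter. For compound 4 the estimate in this assay is 35000 nM, within a range from 15000 nM to 80000 nM.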

Compound 4, half-maximal inhibitory concentration: 34000 nM
The estimate for compound 4 lay 1.0-fold (0.01 log units) above the measured number; the measured number falls inside the stated range.
By their numbers in this assay, from the lowest: compounds 1, 3 and 4 (each within the scatter of the next). At a limit, above all of these: compound 2.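

At this position on the aromatic nitrogen, compound 4 is the only one shown with a benzyl and the only one whose group carries a hydrogen-bond acceptor, yet in this assay the exchange stays as flat as the swaps among phenyl groups. Its step against the 3-bromophenyl is a 1.0-fold higher number from compound 3 to compound 4 (0.00 log units; within the scatter), against the 3,4-dimethylphenyl it is a 1.5-fold higher number from compound 1 to compound 4 (0.16 log units; within the scatter), and against the 4-iodophenyl it is an at least 1.1-fold lower number from compound 2 to compound 4 (0.07 log units; that floor lies within the scatter). Compound 2 remains a limit, not a number: the limit of > 40000 nM in this assay, at which 1 of the 4 values shown sits.

Still open, on these data alone, is whether any group on this nitrogen moves the number beyond the scatter, for instance an amine or a carboxylic acid on the ring, or a longer chain in place of the benzyl. As far as these compounds go, the shared core is the same in all four compounds, so what a change there would do also remains open.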